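This account rests on a few compounds, and the source may have more. Where it says the series, first, only, none or still open, it means among the compounds named here.

Measured so far:
compound 1 `COc1ccc(-c2nc(SCC(=O)c3sc(-c4ccccc4)nc3C)[nH]c(=O)c2C#N)cc1` gives 52.1% in a functional assay on U-87MG ATCC cells for antiproliferative activity against U-87 MG (Homo sapiens), read by MTT assay, with a stated time of 48 h, tested at 50 uM; a higher number here means a weaker effect of the compound at the concentration tested, a lower number a stronger effect;
compound 2 `COc1ccc(-c2nc(C)c(C(=O)CSc3nc(-c4ccc(Cl)cc4)c(C#N)c(=O)[nH]3)s2)cc1` gives 48% in this assay;
compound 3 `Cc1nc(-c2ccccc2)sc1C(=O)CSc1nc(-c2ccccc2)c(C#N)c(=O)[nH]1` gives 77.5% in this assay.

Compound 3 stands highest of the three numbers, so at the concentration tested it shows the weakest effect; compound 1 lies closest to it, and compound 2 furthest away, both gaps beyond the scatter. Within the data shown here, the one step recorded so far, a number 25.4 percentage points higher from compound 1 to compound 3 (beyond the scatter), concerns a different change than the one now followed.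

Compound 4 `Cc1nc(-c2ccccc2)sc1C(=O)CSc1nc(-c2ccc(Cl)cc2)c(C#N)c(=O)[nH]1` differs from compound 3 by chloro in place of hydrogen on an aromatic carbon. Among the measured compounds shown here, no measured step covers exactly this change. The closest guidance comes from compound 1 and compound 2, which differ from each other in the same way, and whose values in this assay lie within the scatter of each other. On that basis the step from compound 3 to compound 4 is expected to stay within the scatter, with at most a slight lowering, estimated as a number 4.5 percentage points lower from compound 3 to compound 4 (within the scatter). Compound 4 is therefore expected to give about 73% in this assay, with a likely range from 58% to 88%.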

Compound 4, a percentage reported as activity, at one concentration (the size of the read-out at that concentration, not a potency): 63.4%
Estimate against measurement, compound 4: 9.6 percentage points above; low and high end bracket the measured number.
By their numbers in this assay, from the lowest: compounds 2 and 1 (each within the scatter of the next); then compound 4; then compound 3.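

Chloro in place of hydrogen on this ring, para to a large group, has a real effect in this assay: it gives a number 14.1 percentage points lower from compound 3 to compound 4 (beyond the scatter). Chloro in place of methoxy at the same place gives a number 11.3 percentage points higher from compound 1 to compound 4 (beyond the scatter), so on this shared core the effect at the concentration tested runs from methoxy, the stronger, through chloro to hydrogen, the weaker. Hydrogen in place of methoxy on the other phenyl ring gives a number 15.4 percentage points higher from compound 2 to compound 4 (beyond the scatter), so losing a methoxy raises the number at both places, by sizes that cannot be told apart: the same change on two cores in this assay, a number 25.4 percentage points higher (beyond the scatter) from compound 1 to compound 3 and a number 15.4 percentage points higher (beyond the scatter) from compound 2 to compound 4, 10 percentage points apart, within the scatter of two such steps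

The compounds shown leave open how an amine or a carboxylic acid at this place would compare with methoxy, chloro and hydrogen, and whether a fluoro, a smaller halogen, would follow chloro. Among these compounds, with only three groups at this place, and one concentration in a single cell line, they also cannot say why the order runs as it does, or whether it would hold for potency.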